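The compounds below may be only part of what the source reports. "The series", "measured", "known", "first", "only" and "open" are said of these compounds alone.

Measured so far:
compound 1 `CSc1ccc(OCc2ccccc2)c(C2=C(c3cccc(C(=O)O)c3)CCC2)c1` – < 3170 nM
compound 2 `CS(=O)(=O)c1ccc(OCc2ccc(F)cc2F)c(C2=C(c3cccc(C(=O)O)c3)CCC2)c1` – < 3170 nM

In an assay on isolated protein for inhibition of prostaglandin E2 receptor EP3 subtype (Homo sapiens) (a lower number here means a stronger inhibitor, a higher number a weaker inhibitor), compound 1 gives < 3170 nM, which is a limit of the assay and not a number. In this assay compound 2 gives < 3170 nM, again a limit and not a number. Compound 2 therefore stands nowhere exact on the numbers shown: both measured values sit at the limit of < 3170 nM in this assay, at which 2 of the 2 values shown sit, so neither compound can be ranked against the other.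

Compound 3 `CS(=O)(=O)c1ccc(OCc2ccccc2)c(C2=C(c3cccc(C(=O)O)c3)CCC2)c1` remains to be measured in this assay. The change from compound 2 is phenyl in place of 2,4-difluorophenyl on a saturated chain carbon bound to an oxygen on an aromatic ring. Within the data shown here, no step between two measured compounds exists, so no measured size of effect can be carried over. The step from compound 2 to compound 3 is expected to be small, a step that the limit leaves unreadable from compound 2 to compound 3, most likely none beyond the scatter. Compound 3 is estimated at 600 nM, within a range of 60 nM to 3170 nM.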

Compound 3, half-maximal inhibitory concentration: < 3170 nM
Compound 3: a limit, no number; the forecaster's own chance of this, stated with the estimate: 65%; the middle value is on the limit's open side.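

In this assay, compound 3 gives only a limit and not a number, so the steps to it from compound 1 and compound 2 cannot be read: the limit of < 3170 nM in this assay, at which 3 of the 3 values shown sit. The compounds shown leave open the exact inhibition by all three and the size of either change.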